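This account rests on a few compounds, and the source may have more. Where it says the series, first, only, none or still open, it means among the compounds named here.

In an assay on HEK293 cells for inhibition of Steryl-sulfatase (Homo sapiens), tested at 0.1 uM (a lower number here means a weaker effect, a higher number a stronger effect of the compound at the concentration tested), three compounds built on one shared core have been measured. Compound 1 `CC(C)CCN(CCC(C)C)c1ccc(C(=O)N2CCc3ccc(OS(N)(=O)=O)cc3C2)cc1` gives 47%, compound 2 `CCN(Cc1cccnc1)c1ccc(C(=O)N2CCc3ccc(OS(N)(=O)=O)cc3C2)cc1` gives 35.7%, and compound 3 `CCN(Cc1ccc(Br)cc1)c1ccc(C(=O)N2CCc3ccc(OS(N)(=O)=O)cc3C2)cc1` gives 78.2%, the highest of the three, since the steps of a number 31.2 percentage points higher from compound 1 to compound 3 (beyond the scatter) and a number 42.5 percentage points higher from compound 2 to compound 3 (beyond the scatter) both lie beyond the scatter, as does a number 11.3 percentage points lower from compound 1 to compound 2 (beyond the scatter). Compound 4 `CCN(Cc1ccncc1)c1ccc(C(=O)N2CCc3ccc(OS(N)(=O)=O)cc3C2)cc1` differs from compound 3 in a single place: pyridin-4-yl in place of 4-bromophenyl on a saturated chain carbon bound to a nitrogen on an aromatic ring. The step that bears most directly on this change is a number 42.5 percentage points higher from compound 2 to compound 3 (beyond the scatter), where pyridin-3-yl gave way to 4-bromophenyl; compound 4 runs that exchange in the opposite direction, so a large fall is expected, a number 40.2 percentage points lower from compound 3 to compound 4 (beyond the scatter). Compound 4 is expected to give 38%, within a range from 20% to 58%.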

Compound 4, a percentage reported as inhibition, at one concentration (the size of the read-out at that concentration, not a potency): 47%
Beside the measured number, compound 4's estimate is 9 percentage points below it; measured number inside the range.
By their numbers in this assay, from the lowest: compound 2; then compounds 1 and 4 (each within the scatter of the next); then compound 3.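

Within this assay and on this saturated chain carbon, pyridin-4-yl in place of 4-bromophenyl gives a number 31.2 percentage points lower from compound 3 to compound 4 (beyond the scatter) so the fall seen with pyridin-3-yl is not confined to that one ring. Pyridin-4-yl in place of pyridin-3-yl gives a number 11.3 percentage points higher from compound 2 to compound 4 (beyond the scatter) so the site of the ring nitrogen counts here. Ethyl((pyridin-4-yl)methyl)amino in place of diisopentylamino gives no change at the digits printed from compound 1 to compound 4 (within the scatter) and so matches it within the scatter. Nothing at hand explains these shifts. From the compounds shown here alone, whether the bromine itself matters stays open, since a plain phenyl or a 4-chlorophenyl group could separate it from the ring.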